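The compounds below may be only part of what the source reports. "The series", "measured", "known", "first", "only" and "open" are said of these compounds alone.

Compound 1 `Clc1cccc(-c2nnc(C(NCc3ccccc3)c3ccc[nH]3)o2)c1` is tested in a functional assay on HT-29 cells (Homo sapiens) for cytotoxicity, read by MTT assay, with a stated time of 24 h (a higher number here means a weaker inhibitor, a lower number a stronger inhibitor), where compound 1 gives 48300 nM. Among the three measured compounds, compound 1 stands second highest; the closest is compound 3 `Brc1ccc(-c2nnc(C(NCc3ccccc3)c3ccc[nH]3)o2)cc1`, which gives 58300 nM, and the furthest is compound 2 `Fc1cc(-c2nnc(C(NCc3ccccc3)c3ccc[nH]3)o2)c(Cl)cc1Cl`, which gives 20000 nM. Compound 4 `Cc1ccc(-c2nnc(C(NCc3ccccc3)c3ccc[nH]3)o2)cc1` differs from compound 1 in one place: 4-methylphenyl in place of 3-chlorophenyl on an aromatic carbon. Two measured steps change the same aryl group. The step of a 1.2-fold higher number from compound 1 to compound 3 (0.08 log units; within the scatter) stays within the scatter, while the step of a 2.4-fold lower number from compound 1 to compound 2 (0.38 log units; beyond the scatter) goes beyond it, though only modestly. Because the exchange for compound 4 resembles the shift seen in a 1.2-fold higher number from compound 1 to compound 3 (0.08 log units; within the scatter), no step beyond the scatter is expected in this assay. Compound 4 is therefore estimated at 55000 nM, within a range of 25000 nM to 120000 nM, an expected step of a 1.1-fold higher number from compound 1 to compound 4 (0.06 log units; within the scatter).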

Compound 4, half-maximal inhibitory concentration: 249000 nM
The estimate for compound 4 lay 4.5-fold (0.66 log units) below the measured number; measured number above the stated range.
By their numbers in this assay, from the lowest: compound 2; then compounds 1 and 3 (each within the scatter of the next); then compound 4.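

In this assay, the phenyl substituent matters more than compounds 1 and 3 suggested: the change to 4-methylphenyl gives a 5.2-fold higher number from compound 1 to compound 4 (0.71 log units; beyond the scatter), and methyl in place of bromo alone gives a 4.3-fold higher number from compound 3 to compound 4 (0.63 log units; beyond the scatter). Against the 2,4-dichloro-5-fluorophenyl group the gap widens to a 12-fold higher number from compound 2 to compound 4 (1.10 log units; beyond the scatter), leaving compound 4, the only compound without a halogen, with the highest number. No available measurement explains this shift.

Open, on these data alone, is how a methoxy group, an amine or a carboxylic acid would fare on this phenyl ring. As far as these compounds go, whether a bare phenyl group sides with compound 4 or with the halogen-bearing compounds is also open.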